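The source may report more compounds than this note shows. Statements on the series, on what has been measured and on what is new or still open speak of the compounds shown alone.

Working notes on the series. Compound 1 `CC[C@@H](Nc1c(C#N)c(-c2ccc(-c3ncccc3C)cc2)nc2cnccc12)C(N)=O` sets the low end: in a physicochemical assay for lipophilicity, read by HPLC, at pH 7.5 (on this read-out lower numbers stand for lower lipophilicity and higher numbers for higher lipophilicity), compound 1 gives 2. For the measured compounds named here, compound 3 `CC[C@@H](Nc1c(C#N)c(-c2ccc(-c3cccc(OC)c3)cc2)nc2cnccc12)C(N)=O` gives 2.7, and the one-place step a number 0.70 log units higher from compound 1 to compound 3 (beyond the scatter) is the only measured step in this set. Compound 2 `CCCCC(Nc1c(C#N)c(-c2ccc(-c3ccccc3OCC)cc2)nc2cnccc12)C(N)=O` stands highest of the three measured numbers: compound 2 gives 3.6, which lies beyond the scatter from both compound 3 and compound 1.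

Compound 4 `CCOc1ccccc1-c1ccc(-c2nc3cnccc3cc2C#N)cc1` differs from compound 2 in one place: a hydrogen atom in place of a group of 9 heavy atoms (6 carbon, 2 nitrogen, 1 oxygen; no ring), on an aromatic carbon. Going by the values given here, the measured step from compound 1 to compound 3 concerns a different part of the molecule, so no measured step bears on this change. What is known is that the group leaving carries two hydrogen-bond donors and two hydrogen-bond acceptors, and that compound 2, with that group in place, is already the highest at 3.6. The expectation is therefore a step upward in this assay, beyond the scatter, with a wide range because nothing in the measured set reports the same change. The expected step is a number 0.90 log units higher from compound 2 to compound 4 (beyond the scatter). For compound 4 the estimate is 4.5, between 3.8 and 5.2.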

Compound 4, distribution coefficient: 3.8
Compound 4: the middle estimate sits 0.70 log units above what was measured; low and high end bracket the measured number.
By their numbers in this assay, from the lowest: compound 1; then compound 3; then compounds 2 and 4 (each within the scatter of the next).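

In this assay, a hydrogen atom in place of the group of 9 heavy atoms (6 carbon, 2 nitrogen, 1 oxygen; no ring), on the aromatic carbon ortho to a cyano group, gives a number 0.20 log units higher from compound 2 to compound 4 (within the scatter). For the compounds shown here, this is the first measured step at this position, and it shows that, with the rest of compound 2 unchanged, this read-out does not separate this group, with its 2 hydrogen-bond donors and 2 hydrogen-bond acceptors, from a hydrogen atom. Nothing available accounts for this result, so it stands as an observation without an explanation.

The compounds shown leave open whether a group with a different make-up on this aromatic carbon, such as an amine, a carboxylic acid or a plain butyl chain, would also stay within the scatter of compound 4. Going by these compounds alone, they also leave open whether a hydrogen atom at this position would give a similarly small step with the aromatic groups of compound 1 or compound 3 in place of the one in compound 2.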